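A few compounds are considered here, and "the series" means these few. Any claim that something is new, unique, unknown or untested is made for them only; others in the source may bear on it.

Measured compounds:
compound 1 `CO[C@@H]1[C@H](N(C)c2ncc(-c3c[nH]c4ccc(F)cc34)s2)C[C@H]2O[C@]1(C)n1c3ccccc3c3c4c(c5c6cc(Cl)ccc6n2c5c31)C(=O)NC4`, > 10000 nM
compound 2 `CO[C@@H]1[C@H](N(C)c2ncc(-c3c[nH]c4ccc(F)cc34)s2)C[C@H]2O[C@]1(C)n1c3ccccc3c3c4c(c5c6cc(Br)ccc6n2c5c31)C(=O)NC4`, > 10000 nM
compound 3 `CO[C@@H]1[C@H](N(C)c2ncc(-c3c[nH]c4ccc(Cl)cc34)s2)C[C@H]2O[C@]1(C)n1c3ccccc3c3c4c(c5c6cc(Br)ccc6n2c5c31)C(=O)NC4`, > 10000 nM

In an ADME assay on PBMC cells (Homo sapiens) for cytotoxicity, read by CellTiter-Glo, with a stated time of 72 h (on this read-out higher numbers stand for weaker inhibition and lower numbers for stronger inhibition), compound 1 gives > 10000 nM, which is a limit of the assay and not a number. In this assay compound 2 gives > 10000 nM, again a limit. In this assay compound 3 gives > 10000 nM, also a limit. The step that the two limits leave unreadable from compound 1 to compound 2 is therefore unreadable, as is the step that the two limits leave unreadable from compound 2 to compound 3; all three values sit at the limit of > 10000 nM in this assay, at which 3 of the 3 values shown sit.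

Compound 2 differs from compound 1 by bromo in place of chloro on an aromatic carbon. The difference between the cores of compound 1 and compound 3 is not broken down here.

Compound 4 `CO[C@@H]1[C@H](N(C)c2ncc(-c3c[nH]c4ccc(Br)cc34)s2)C[C@H]2O[C@]1(C)n1c3ccccc3c3c4c(c5c6cc(Br)ccc6n2c5c31)C(=O)NC4` has not been measured in this assay. It differs from compound 3 by bromo in place of chloro on an aromatic carbon. This is the same kind of change as that from compound 1 to compound 2, but not the same: around the place, the earlier change sits on a ring that is part of a fused or bridged system of eight rings, whereas here the ring is part of a fused or bridged system of two rings.

For compound 4 the step that the limit leaves unreadable from compound 3 to compound 4 is expected to remain unreadable in the same way, because compound 3 sits at the limit of > 10000 nM in this assay, at which 3 of the 3 values shown sit, and every measured compound sits there too. Compound 4 is expected to give 20000 nM in this assay, most likely reported only as a limit, with a plausible range of 10000 nM to 60000 nM.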

Compound 4, half-maximal inhibitory concentration: > 10000 nM
Compound 4: no number, only a limit (the forecaster's own chance of this, stated with the estimate: 90%); the middle value lies beyond the limit too.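

In this assay compound 4 gives > 10000 nM as a limit of the assay and not a number. The steps from compound 3 and from compound 2 to compound 4 cannot be read, because the values on both sides are limits: the limit of > 10000 nM in this assay, at which 4 of the 4 values shown sit. The compounds shown leave open how far each value lies beyond the limit and whether any halogen exchange changes cytotoxicity in these cells.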